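The source may report more compounds than this note shows. Statements on the series, on what has been measured and on what is new or still open speak of the compounds shown alone.

Measured so far:
compound 1 `CC(=O)Nc1ccc2c(C)cc(=O)[nH]c2c1` gives 0.995 in a physicochemical assay for lipophilicity; on this read-out lower numbers stand for lower lipophilicity and higher numbers for higher lipophilicity
compound 2 `Cc1cc(=O)[nH]c2cc(NC(=O)c3ccc(F)cc3)ccc12` gives 1.61 in this assay

Compound 1 stands lowest of the two numbers in this assay; the nearest is compound 2, and the step of a number 0.62 log units higher from compound 1 to compound 2 (beyond the scatter) lies beyond the scatter. Compound 3 `Cc1cc(=O)[nH]c2cc(NC(=O)c3ccc(Cl)cc3)ccc12` is not yet measured in this assay. It differs from compound 1 by 4-chlorophenyl in place of methyl on a carbonyl carbon. Going by the values given here, the one measured step that bears on this is a number 0.62 log units higher from compound 1 to compound 2 (beyond the scatter), where a 4-fluorophenyl group entered at the same carbonyl carbon in place of methyl. Compound 3 carries a 4-chlorophenyl group at that position instead, a change of the same kind. A step of similar size in the same direction is therefore expected, so that compound 1 to compound 3 should read as a number 1.01 log units higher from compound 1 to compound 3 (beyond the scatter), possibly somewhat larger than the step to compound 2. Compound 3 is estimated at 2 in this assay, within a range of 1.5 to 2.5.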

Compound 3, partition coefficient: 1.69
Compound 3: the middle estimate sits 0.31 log units above what was measured, and the stated range covers the measured number.
By their numbers in this assay, from the lowest: compound 1; then compounds 2 and 3 (each within the scatter of the next).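

In this assay, the step of a number 0.70 log units higher from compound 1 to compound 3 (beyond the scatter) shows that the rise seen with 4-fluorophenyl on this carbonyl carbon is not confined to that one group. Chloro in place of fluoro on the aromatic carbon gives a number 0.08 log units higher from compound 2 to compound 3 (within the scatter), so this read-out does not separate compound 2 from compound 3, and the choice between these two halogens makes no measurable difference here. No measurement at hand speaks to the origin of either step.

Plain phenyl on the carbonyl carbon would show what the ring gives without a halogen, and it remains open whether a longer alkyl chain or cyclohexyl would give a similar step. As far as these compounds go, the effect of an amine or a carboxylic acid on the ring in place of the halogen also remains open.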